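The source may report more compounds than this note shows. Statements on the series, on what has been measured and on what is new or still open speak of the compounds shown alone.

Compound 3 `CN(CCCNS(=O)(=O)c1cc(C(F)(F)F)cc(C(F)(F)F)c1)Cc1ccccc1` is the starting point. In a functional assay on HT-29 cells (Homo sapiens) for inhibition, read by MTT assay, with a stated time of 72 h (a lower number here means a stronger inhibitor of growth, a higher number a weaker inhibitor of growth), compound 3 gives > 50000 nM, which is a limit rather than a number. That places compound 3 at the limit of > 50000 nM in this assay, at which 1 of the 3 values shown sits. Compound 1 `O=S(=O)(NCCCNCc1ccc(Cl)c(Cl)c1)c1cc(C(F)(F)F)cc(C(F)(F)F)c1` gives 4700 nM in this assay, and compound 2 `O=S(=O)(NCCCNCc1ccc(C(F)(F)F)cc1)c1cc(C(F)(F)F)cc(C(F)(F)F)c1` gives 2900 nM. Between them, a 1.6-fold lower number from compound 1 to compound 2 (0.21 log units; within the scatter), whereas an at least 10-fold higher number from compound 1 to compound 3 (1.02 log units; beyond the scatter). Compound 4 `O=S(=O)(NCCCNCc1cccc(Cl)c1)c1cc(C(F)(F)F)cc(C(F)(F)F)c1` differs from compound 3 in one place: (3-chlorobenzyl)amino in place of benzyl(methyl)amino on a saturated chain carbon, three bonds along the chain from a sulfonamide nitrogen. Compound 4 thus carries a benzylamino group with a hydrogen-bond donor, as compound 1 and compound 2 do, so the expectation is a large drop back toward their values, an at least 12-fold lower number from compound 3 to compound 4 (1.09 log units; beyond the scatter). For compound 4 the estimated value is 4000 nM, with a range from 1500 nM to 13000 nM.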

Compound 4, concentration for 50% growth inhibition: 14000 nM
For compound 4 the middle estimate is 3.5-fold (0.54 log units) below the measured one, and the stated range ends below it.
By their numbers in this assay, from the lowest: compounds 2 and 1 (each within the scatter of the next); then compound 4. At a limit, above all of these: compound 3.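

At this chain position, (3-chlorobenzyl)amino in place of benzyl(methyl)amino gives an at least 3.5-fold lower number from compound 3 to compound 4 (0.55 log units; beyond the scatter), and that size is only a minimum. Compound 3 has a limit, not a number: the limit of > 50000 nM in this assay, at which 1 of the 4 values shown sits.
The ring substituents also matter beyond the scatter, which compound 1 and compound 2 alone did not show: hydrogen in place of chloro gives a 3.0-fold higher number from compound 1 to compound 4 (0.47 log units; beyond the scatter), and 3-chlorophenyl in place of 4-(trifluoromethyl)phenyl gives a 4.8-fold higher number from compound 2 to compound 4 (0.68 log units; beyond the scatter).

From the compounds shown here alone, this step changes both the amine methyl and the ring chloro, so the share of each stays open. Also open, going by these compounds, is how a methoxy group on the ring or a longer chain would behave.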